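Azido in place of acetamido: expected step

This account rests on a few compounds, and the source may have more. Where it says the series, first, only, none or still open, it means among the compounds named here.

Going by the values given here, in a functional assay on NCI-H460 cells (Homo sapiens) for positive allosteric modulation, read by MTT assay, with stated times of 2 h and 72 h, tested at 10 uM (a lower number here means a stronger inhibitor, a higher number a weaker inhibitor), compound 2 `COc1cccc(-n2nnc(-c3ccccc3NC(=O)c3ccc(NC(C)=O)cc3)n2)c1` gives the higher of the two numbers so far (520 nM), while compound 1 `CCCc1ccc(C(=O)Nc2ccccc2-c2nnn(-c3cccc(OC)c3)n2)cc1` gives 121 nM on the same read-out. Compound 3 `COc1cccc(-n2nnc(-c3ccccc3NC(=O)c3ccc(N=[N+]=[N-])cc3)n2)c1` carries azido in place of acetamido on an aromatic carbon, para to a large group (azido in place of acetamido on an aromatic carbon). Among the compounds with values here, the only measured step at this place is a 4.3-fold higher number from compound 1 to compound 2 (0.63 log units; beyond the scatter) and no azido compound has a number yet, so the basis is thin. The step expected in this assay is a 2.4-fold lower number from compound 2 to compound 3 (0.37 log units; beyond the scatter) and is modest, towards a lower number. For compound 3 the estimated value is 220 nM (expected range 80 nM to 600 nM).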

Compound 3, half-maximal inhibitory concentration: 415 nM
For compound 3 the middle estimate is 1.9-fold (0.28 log units) below the measured one, within the range that was stated.
By their numbers in this assay, from the lowest: compound 1; then compounds 3 and 2 (each within the scatter of the next).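

In this assay the position tolerates azido in place of acetamido, with a 1.3-fold lower number from compound 2 to compound 3 (0.10 log units; within the scatter) even though the hydrogen-bond donor counted on acetamido is gone. Propyl remains apart from azido as well as from acetamido, with a 3.4-fold higher number from compound 1 to compound 3 (0.54 log units; beyond the scatter) as the second step beyond the scatter from propyl at this position. Nothing measured here explains either step.

From the compounds shown here alone, whether the gap from propyl depends on chain length or on the atom attached to the ring remains open. An ethyl or butyl chain, a methoxy group or an amine at this position would help separate these readings.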